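The source may report more compounds than this note shows. Statements on the series, on what has been measured and on what is new or still open speak of the compounds shown alone.

Compound 1 `Cc1nc(N)c2c(-c3ccsc3)cn([C@@H]3O[C@H](CO)[C@@H](O)[C@H]3O)c2n1`: > 20000 nM
Compound 2 `C#Cc1cn([C@@H]2O[C@H](CO)[C@@H](O)[C@H]2O)c2nc(C)nc(N)c12`: 12600 nM

Among the compounds with values here, in a functional assay on CEM-DNR-bulk cells (Homo sapiens), read by MTT assay, with a stated time of 72 h (on this read-out lower numbers stand for stronger inhibition and higher numbers for weaker inhibition), compound 2 gives 12600 nM, the only true number so far. Compound 1 reads > 20000 nM, which is a limit of the assay. The next candidate is compound 3 `Cc1nc(N)c2c(I)cn([C@@H]3O[C@H](CO)[C@@H](O)[C@H]3O)c2n1`, and the change is iodo in place of ethynyl on an aromatic carbon, the same carbon that changes between the two measured compounds. Within the data shown here, one measured step bears on this: an at least 1.5-fold lower number from compound 1 to compound 2 (0.20 log units; that floor lies within the scatter). With a limit at one end, that step shows only a floor for its size, and it gives no firm sign that this carbon moves the number much. In this assay, no step beyond the scatter is therefore expected, and the expected step is a 1.1-fold lower number from compound 2 to compound 3 (0.06 log units; within the scatter). For compound 3 the estimated value is 11000 nM, with an expected range from 3500 nM to 30000 nM.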

Compound 3, half-maximal inhibitory concentration: 3480 nM
For compound 3 the middle estimate is 3.2-fold (0.50 log units) above the measured one; measured number outside the range, below it.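

In this assay, within the data shown here, the group on this aromatic carbon clearly moves the number: iodo in place of ethynyl gives a 3.6-fold lower number from compound 2 to compound 3 (0.56 log units; beyond the scatter) and is the first step here that lies beyond the scatter. Iodo in place of thiophen-3-yl gives an at least 5.7-fold lower number from compound 1 to compound 3 (0.75 log units; beyond the scatter) and this makes compound 3, with its single iodine atom on that carbon, the most potent of the compounds shown. The size of that second step is only a floor because compound 1 sits at a limit of the assay: the limit of > 20000 nM in this assay, at which 1 of the 3 values shown sits.

Going by these compounds, whether the drop in the number belongs to iodine in particular stays open, and a bromo, a chloro or an amine on the same carbon would help to settle that. On these data alone, how far the number would move with changes elsewhere on the shared core also remains unknown.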